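Swapping a carbamate chain for benzyl on a bis-aziridinyl quinone

A few compounds are considered here, and "the series" means these few. Any claim that something is new, unique, unknown or untested is made for them only; others in the source may bear on it.

Measured so far:
compound 1, `CC1=C(N2CC2)C(=O)C(CC(C)OC(N)=O)=C(N2CC2)C1=O`, 6.14
compound 2, `CN(C)C(=O)OCCC1=C(N2CC2)C(=O)C(CCOC(=O)N(C)C)=C(N2CC2)C1=O`, 5.16
compound 3, `CC(C)C1=C(N2CC2)C(=O)C=C(N2CC2)C1=O`, 5.68

All three compounds share a quinone core carrying two aziridine rings and were tested in a functional assay on L1210 cells (Mus musculus), with a stated time of 12 days; a lower number here means a less potent compound, a higher number a more potent compound, by a factor of ten per unit of this negative logarithm. Compound 1 gives 6.14 and stands highest of the three numbers. Compound 3 comes nearest, and its value of 5.68 lies beyond the scatter below compound 1. Compound 2 is furthest away, and its 5.16 is also beyond the scatter below compound 1.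

The new compound is compound 4, `CC1=C(N2CC2)C(=O)C(Cc2ccccc2)=C(N2CC2)C1=O`, which has not yet been measured in this assay. Compared with compound 1, the change is a group of 6 heavy atoms (6 carbon; one six-membered aromatic ring of carbon only) in place of a group of 6 heavy atoms (3 carbon, 1 nitrogen, 2 oxygen; no ring), on a saturated chain carbon bound to a double-bonded ring carbon.

No measured pair differs in exactly this way, so the size of the step cannot be read from a shown difference. Compound 3, which carries no carbamate, sits beyond the scatter below compound 1, and compound 2, which carries two carbamates, sits lower still, so the carbamate alone does not decide the outcome. The expected step from compound 1 to compound 4 is a number 0.44 log units lower from compound 1 to compound 4 (beyond the scatter), a modest fall. Compound 4 is therefore estimated at 5.7, with a range from 5 to 6.4.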

Compound 4, logarithm of the reciprocal of the active concentration, log(1/C): 4.85
For compound 4 the middle estimate is 0.85 log units above the measured one, outside the stated range (below it).
By their numbers in this assay, from the lowest: compound 4; then compound 2; then compound 3; then compound 1.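

In this assay, the swap at this saturated chain carbon bound to a double-bonded ring carbon gives a number 1.29 log units lower from compound 1 to compound 4 (beyond the scatter), the first direct measure of how much this place matters. The two groups have the same count of 6 heavy atoms, so this pair shows that keeping that count does not keep the number: the group that leaves, with its nitrogen and oxygen atoms, 1 hydrogen-bond donor and 2 hydrogen-bond acceptors, gives way to a phenyl made of carbon alone and the value falls sharply. Nothing measured here explains the fall.

With one pair, the loss cannot be assigned to any single feature of the change, such as the phenyl ring itself or the absence of the nitrogen and oxygen atoms of the group that leaves. The compounds shown also leave open how a simple hydroxyl, an amine, a carboxylic acid or a longer chain of carbon atoms would fare at this same place, and any of these would help to show which part of the original group carries the higher number.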